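The compounds below may be only part of what the source reports. "The series", "measured", "known", "first", "only" and "open" are said of these compounds alone.

Compound 1 `O=C(NC(=S)N1CCc2c(OCCCCCOc3ccc(Cl)cc3)cccc21)C1CCCC1`. In an ADME assay on Huh-7 cells (Homo sapiens) for cytotoxicity (on this read-out lower numbers stand for higher toxicity in this test and higher numbers for lower toxicity in this test), compound 1 gives > 50000 nM, which is a limit of the assay rather than a number.
Compound 2 `O=C(NC(=S)N1CCc2c(OCCCCCOc3ccc(Cl)cc3)cccc21)c1ccno1`. In this assay compound 2 gives 37100 nM.

Among the compounds with values here, compound 2 therefore holds the only actual number in this small set; the other value is a limit. Within the data shown here, the one measured step, an at least 1.3-fold lower number from compound 1 to compound 2 (0.12 log units; that floor lies within the scatter), rests on the limit of > 50000 nM in this assay, at which 1 of the 2 values shown sits, and its floor lies within the scatter, so it shows no clear change in either direction. Compound 3 `S=C(NC(=S)N1CCc2c(OCCCCCOc3ccc(Cl)cc3)cccc21)Oc1ccccc1` differs from compound 2 in one place: a group of 9 heavy atoms (7 carbon, 1 oxygen, 1 sulfur; one six-membered aromatic ring of carbon only) in place of a group of 7 heavy atoms (4 carbon, 1 nitrogen, 2 oxygen; one five-membered aromatic ring with 2 hetero atoms), on an amide-type nitrogen. Among the measured compounds shown here, no measured step involves this kind of change, and the only step that was measured shows nothing beyond the scatter. On that basis, compound 3 is expected to give a number close to that of compound 2, and the step of a 1.1-fold higher number from compound 2 to compound 3 (0.03 log units; within the scatter) is expected to stay within the scatter. The estimate for compound 3 in this assay is 40000 nM, with a range from 15000 nM to 100000 nM.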

Compound 3, half-maximal cytotoxic concentration: > 50000 nM
Compound 3: only a limit was reported; the forecaster's own chance of this, stated with the estimate: 40%; middle value at least 1.2-fold (0.09 log units) away from the limit.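

Placing the group of 9 heavy atoms, with its six-membered aromatic ring of carbon only, on the amide-type nitrogen in place of (1,2-oxazol-5-yl)carbonyl gives an at least 1.3-fold higher number from compound 2 to compound 3 (0.12 log units; that floor lies within the scatter), so this change shows no clear effect in this assay. Compound 1 and compound 3 both carry limits, and the step between them cannot be read. This place on the amide-type nitrogen has now held three different groups without a clear change in the values shown, but most of those values sit at one limit: the limit of > 50000 nM in this assay, at which 2 of the 3 values shown sit.

On these data alone, it remains open whether a group carrying an amine or a carboxylic acid at this place would give a number clearly lower than that of compound 2. As far as these compounds go, how far compound 1 and compound 3 actually lie from their limit also remains open.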